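Cytotoxicity notes: aryl swap from compound 3 to compound 4

The compounds below may be only part of what the source reports. "The series", "measured", "known", "first", "only" and "open" are said of these compounds alone.

Among the compounds with values here, compound 3 `Cc1ccc(C(O)c2cc(Cl)ccc2OCC(=O)Nc2ccc(S(N)(=O)=O)cc2C)c(C)c1` gives 26400 nM in an ADME assay on C8166 cells (Homo sapiens) for cytotoxicity, read by MTT assay (on this read-out higher numbers stand for lower toxicity in this test and lower numbers for higher toxicity in this test), the lowest of the three numbers so far. The nearest is compound 1 `Cc1ccc(C(O)c2cc(Cl)ccc2OCC(=O)Nc2ccc(S(N)(=O)=O)cc2C)cc1` at 38700 nM; the gap is a 1.5-fold lower number from compound 1 to compound 3 (0.17 log units; within the scatter). The furthest is compound 2 `Cc1cc(S(N)(=O)=O)ccc1NC(=O)COc1ccc(Cl)cc1C(O)c1cccc(C)c1C` at 218000 nM; that gap is an 8.3-fold lower number from compound 2 to compound 3 (0.92 log units; beyond the scatter). Compound 4 `Cc1cc(S(N)(=O)=O)ccc1NC(=O)COc1ccc(Cl)cc1C(O)c1cc(Cl)cc(C#N)c1` has not yet been measured. Its change from compound 3 is 3-chloro-5-cyanophenyl in place of 2,4-dimethylphenyl on a saturated chain carbon bound to an aromatic carbon and an oxygen on a saturated carbon.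

Within the data shown here, no measured step touches the entering group. Among the measured compounds shown here, the steps that bear on it are the two swaps at the same place among methyl-substituted phenyl groups: a 5.6-fold higher number from compound 1 to compound 2 (0.75 log units; beyond the scatter) and an 8.3-fold lower number from compound 2 to compound 3 (0.92 log units; beyond the scatter), both modest and in opposite directions, plus the within-scatter change a 1.5-fold lower number from compound 1 to compound 3 (0.17 log units; within the scatter). Those steps show that exchanging the aryl group at this position can move the number in this assay by a modest amount either way, without a clear direction. Given that, for compound 4 a step of a 1.7-fold higher number from compound 3 to compound 4 (0.23 log units; within the scatter) is expected, leaning toward a somewhat higher number, with wide uncertainty. Compound 4 is estimated at 45000 nM, with a range from 12000 nM to 170000 nM in this assay.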

Compound 4, half-maximal cytotoxic concentration: 31600 nM
For compound 4 the middle estimate is 1.4-fold (0.15 log units) above the measured one, and the stated range covers the measured number.
By their numbers in this assay, from the lowest: compounds 3, 4 and 1 (each within the scatter of the next); then compound 2.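

Cytotoxicity at this position does not require a methyl-substituted phenyl group: in this assay, 3-chloro-5-cyanophenyl stays within the scatter of two of the methyl-substituted groups, with a 1.2-fold higher number from compound 3 to compound 4 (0.08 log units; within the scatter) and a 1.2-fold lower number from compound 1 to compound 4 (0.09 log units; within the scatter). The 2,3-dimethylphenyl group of compound 2 remains the only one set apart among the four compounds, with a 6.9-fold lower number from compound 2 to compound 4 (0.84 log units; beyond the scatter), so the high number is not shared by this first aryl group carrying a chlorine and a nitrile. No supporting data are available to explain the separate place of compound 2.

On these data alone, it remains open whether the number seen with 2,3-dimethylphenyl is specific to that group or recurs with related groups at this place, such as 2,3-dichlorophenyl or 2,3-dimethoxyphenyl. Also open, as far as these compounds go, is how the number responds when the aryl group at this saturated chain carbon gives way to a cyclohexyl group, or when the phenyl group carries an amine or a carboxylic acid.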